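This account rests on a few compounds, and the source may have more. Where it says the series, first, only, none or still open, it means among the compounds named here.

Series notes. Compound 1 `Cc1cc(C(N)=O)ccc1-c1sc(Cc2cccc(C(F)(F)F)c2)nc1C`, compound 2 `Cc1nc(Cc2cccc(C(F)(F)F)c2)sc1-c1ccc(C(N)=O)c(F)c1` and compound 3 `COc1cccc(Cc2nc(C)c(-c3ccc(C(N)=O)c(C)c3)s2)c1` share one core and differ in the substituted benzyl arm and in the group on the carboxamide-bearing ring. In a functional assay on cells for agonist activity at G-protein coupled receptor 52 (Homo sapiens), read by AlphaScreen and cAMP accumulation, with a stated time of 30 min (on this read-out lower numbers stand for smaller maximal responses and higher numbers for larger maximal responses), compound 1 gives 87%, compound 2 gives 84% and compound 3 gives 85%. The three numbers lie within the usual scatter of one another, so compound 3 is not set apart from compound 1 or compound 2 on this read-out, and no ordering among them is claimed.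

Compound 4 `Cc1cc(-c2sc(Cc3cccc(Cl)c3)nc2C)ccc1C(N)=O` is not yet measured. It differs from compound 3 as follows: chloro in place of methoxy on an aromatic carbon. Within the data shown here, no step between measured compounds isolates this change. Given that the maximal responses of compounds 1, 2 and 3 all sit close together, the step from compound 3 to compound 4 is expected to be no change at the digits printed from compound 3 to compound 4 (within the scatter), that is nothing beyond the scatter. Compound 4 is thus estimated at 85%, in a range from 72% to 96%.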

Compound 4, largest response reached (Emax), in percent of the reference or control that the assay uses: 75%
Compound 4: middle estimate off by 10 percentage points, on the high side; measured number inside the range.
By their numbers in this assay, from the lowest: compounds 4, 2, 3 and 1 (each within the scatter of the next, the first and the last beyond it).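

Among these compounds, this is the only single-change step so far, and it isolates the 3-methoxyphenyl to 3-chlorophenyl change. In this assay it gives a number 10 percentage points lower from compound 3 to compound 4 (within the scatter), so this aromatic carbon carries either chloro or methoxy with no step beyond the scatter. Nothing at hand bears on the reason for the size of this step.

Still open, from the compounds shown here alone, is whether an amine, a carboxylic acid or a longer chain on this aromatic carbon would keep the maximal response in the same range. Also open, going by these compounds, is whether the same change reads alike on the core of compound 1.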